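Replacing Benzyloxycarbonyl with Cyanomethyl on the Shared Core

The compounds below may be only part of what the source reports. "The series", "measured", "known", "first", "only" and "open" are said of these compounds alone.

In a functional assay on A 172 cells (Homo sapiens) for cytotoxicity, read by colorimetric assay and MTT assay (a lower number here means a stronger inhibitor, a higher number a weaker inhibitor), compound 1 `CCOC(=O)Cn1c(=O)c(-c2ccc(OC)cc2)cc2c(OC)cc(OC)cc21` gives 10000 nM. Compound 2 `COc1ccc(-c2cc3c(OC)cc(OC)cc3n(CC(=O)OCc3ccccc3)c2=O)cc1` gives 10000 nM, level with compound 1. The change to compound 3 `COc1ccc(-c2cc3c(OC)cc(OC)cc3n(CCC#N)c2=O)cc1` is cyanomethyl in place of benzyloxycarbonyl on a saturated chain carbon bound to an aromatic nitrogen. Among the measured compounds shown here, only one measured step bears on this, no change at the digits printed from compound 1 to compound 2 (within the scatter), where phenyl replaced methyl and the carbonyl group stayed. It is a weak guide, since this new change removes that carbonyl group. The expected size of no change at the digits printed from compound 2 to compound 3 (within the scatter) is none beyond the scatter in this assay. For compound 3 the estimate is 10000 nM, with an expected range of 4000 nM to 20000 nM.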

Compound 3, half-maximal inhibitory concentration: 10000 nM
The estimate for compound 3 equals the measured number at the digits printed; the measured number falls inside the stated range.
By their numbers in this assay, from the lowest: compounds 1, 2 and 3 (each within the scatter of the next).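

In this assay cyanomethyl in place of benzyloxycarbonyl gives no change at the digits printed from compound 2 to compound 3 (within the scatter) and cyanomethyl in place of ethoxycarbonyl gives no change at the digits printed from compound 1 to compound 3 (within the scatter) even though the swap removes the carbonyl group and, from compound 2, the aromatic ring as well. Across these three compounds, then, the number holds with or without a carbonyl group on this chain. Nothing available explains why the number stays level.

From the compounds shown here alone, whether an amine, a carboxylic acid or a longer chain at this place would shift the number remains open. With all three compounds level, nothing yet shows that this position can affect the number at all.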